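The source may report more compounds than this note shows. Statements on the series, on what has been measured and on what is new or still open speak of the compounds shown alone.

For the measured compounds named here, in an ADME assay on Vero cells (Chlorocebus sabaeus) for cytotoxicity, read by sulforhodamine B assay, with a stated time of 3 days (on this read-out lower numbers stand for higher toxicity in this test and higher numbers for lower toxicity in this test), compound 2 `CC1=C(C(=O)Nc2ccc(Cl)cc2)C(c2ccncc2)C(C(=O)Nc2ccc(Cl)cc2)=C(C)N1` gives 78 ug/mL, the higher of the two numbers so far, and compound 1 `CC1=C(C(=O)Nc2ccc(Cl)cc2)C(c2ccco2)C(C(=O)Nc2ccc(Cl)cc2)=C(C)N1` gives 24 ug/mL. Compound 3 `CC1=C(C(=O)Nc2ccc(Cl)cc2)CC(C(=O)Nc2ccc(Cl)cc2)=C(C)N1` carries hydrogen in place of pyridin-4-yl on a saturated ring carbon. Going by the values given here, one measured step bears on this change: a 3.3-fold higher number from compound 1 to compound 2 (0.51 log units; beyond the scatter), made on the same carbon. Among the compounds with values here, it shows that the group there can move the number by a modest amount, but it only exchanges one ring for another, and no measured compound lacks a ring at this carbon. The direction is therefore weakly supported. Compound 2 holds the top number of only two, so some drift towards compound 1 at 24 ug/mL is not excluded, and a lower number is the working expectation. The expected step is a 2.0-fold lower number from compound 2 to compound 3 (0.29 log units; within the scatter), modest at most and in this assay no larger than the measured one. For compound 3 the estimated value is 40 ug/mL, with an expected range from 14 ug/mL to 110 ug/mL.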

Compound 3, half-maximal cytotoxic concentration: 40 ug/mL
For compound 3 middle estimate and measured number coincide at the digits printed; the range from low to high includes it.
By their numbers in this assay, from the lowest: compounds 1, 3 and 2 (each within the scatter of the next, the first and the last beyond it).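

For the compounds shown here, compound 3 is the first with no ring on this saturated ring carbon, and it gives a 2.0-fold lower number from compound 2 to compound 3 (0.29 log units; within the scatter) and a 1.7-fold higher number from compound 1 to compound 3 (0.22 log units; within the scatter) in this assay as the two readings of ring removal. Going by these compounds alone, replacing either pyridin-4-yl or furan-2-yl with hydrogen therefore stays within the scatter, so neither ring is needed at this carbon for a number of this size, whereas the ring exchange, a 3.3-fold higher number from compound 1 to compound 2 (0.51 log units; beyond the scatter) and so beyond the scatter, remains the only larger step. No measured finding accounts for these steps.

Still open, going by these compounds, is whether a methyl, an aminomethyl or a longer alkyl chain on this carbon would stay within the scatter of compound 3. Also open, on these data alone, is whether a phenyl ring here would read with compound 1 or with compound 2.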